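The compounds below may be only part of what the source reports. "The series", "measured", "known", "first", "only" and "open" are said of these compounds alone.

Measured so far in a functional assay on the whole organism (strain Swiss) with Mus musculus as the target, in the maximal electroshock model, with a stated time of 0.25 h, at a dose of 300 mg/kg by the intraperitoneal route; a higher number here means a stronger effect of the compound at the dose given, a lower number a weaker effect:
compound 1 `CCC(C(=O)N1CCN(c2ccccc2F)CC1)N1C(=O)CCC1=O`: 100%
compound 2 `CCC(C(=O)N1CCN(c2ccc(C(F)(F)F)cc2)CC1)N1C(=O)CCC1=O`: 25%

In this assay compound 2 gives 25%, the lower of the two numbers, and compound 1 gives 100%, a gap beyond the scatter. Compound 3 `CCC(C(=O)N1CCN(c2ccccc2)CC1)N1C(=O)CCC1=O` is not yet measured. Against compound 2 the change is hydrogen in place of trifluoromethyl on an aromatic carbon. Among the measured compounds shown here, no measured pair shares this change, so the size of the step is open; an upward step is expected here because compound 2 sits at 25% while compound 1 reaches 100%. For compound 3 an activity of 65% is estimated, within 30% to 100%. The expected step of a number 40 percentage points higher from compound 2 to compound 3 (beyond the scatter) is upward.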

Compound 3, a percentage reported as activity, at one dose (the size of the read-out at that dose, not a potency): 75%
The estimate for compound 3 lay 10 percentage points below the measured number, and the stated range covers the measured number.
By their numbers in this assay, from the lowest: compound 2; then compound 3; then compound 1.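

In this assay, hydrogen in place of trifluoromethyl on this aromatic carbon gives a number 50 percentage points higher from compound 2 to compound 3 (beyond the scatter), so the read-out responds strongly to the group held here. Hydrogen in place of fluoro gives a number 25 percentage points lower from compound 1 to compound 3 (beyond the scatter), so against hydrogen the two groups part in direction: fluoro goes with the higher number, trifluoromethyl with the lower. Nothing at hand accounts for either step. Fluoro and trifluoromethyl alone cannot separate the effect of the group from that of the ring carbon it occupies. As far as these compounds go, how an amine or a carboxylic acid on this carbon would fare remains open.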